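Swapping Halogens on the Benzyl Group of Compound 1

A few compounds are considered here, and "the series" means these few. Any claim that something is new, unique, unknown or untested is made for them only; others in the source may bear on it.

Measured compounds:
compound 1, `CCCn1c(=O)c2nc(-c3cnn(Cc4cc(Cl)ccc4Cl)c3)[nH]c2n(CCC)c1=O`, 29 nM
compound 2, `CCCn1c(=O)c2c(nc(-n3cccn3)n2Cc2ccccc2)n(CCC)c1=O`, > 5800 nM

Among the measured compounds shown here, in an in vitro assay on HEK293 cells for displacement of a labelled ligand from adenosine receptor A2b (Homo sapiens) (on this read-out higher numbers stand for weaker inhibition and lower numbers for stronger inhibition), compound 1 gives 29 nM, which is the only number among the two measured compounds. Compound 2, `CCCn1c(=O)c2c(nc(-n3cccn3)n2Cc2ccccc2)n(CCC)c1=O`, reaches only a limit of this assay, reported as > 5800 nM, and this limit is also what the evidence records in the limit of > 5800 nM in this assay, at which 1 of the 2 values shown sits. For the measured compounds named here, because no pair of measured compounds differs in a single place, no measured step exists, and compound 1 stands alone as the reference point. Compound 3, `CCCn1c(=O)c2nc(-c3cnn(Cc4c(F)cc(F)cc4F)c3)[nH]c2n(CCC)c1=O`, differs from compound 1 by 2,4,6-trifluorophenyl in place of 2,5-dichlorophenyl on a saturated chain carbon bound to an aromatic nitrogen. With no comparable step shown, the change is expected to be a modest weakening, with the step from compound 1 to compound 3 estimated as a 2.1-fold higher number from compound 1 to compound 3 (0.32 log units; beyond the scatter), which may still lie within the scatter. Compound 3 is therefore expected to give 60 nM, with a range from 15 nM to 250 nM.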

Compound 3, inhibition constant: 650 nM
Beside the measured number, compound 3's estimate is 11-fold (1.03 log units) below it; measured number above the stated range.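

In this assay, replacing 2,5-dichlorophenyl with 2,4,6-trifluorophenyl gives a 22-fold higher number from compound 1 to compound 3 (1.35 log units; beyond the scatter), the first measured step from compound 1. It shows that this place, on a saturated chain carbon bound to an aromatic nitrogen, is sensitive to the halogens on the ring, even though both rings are six-membered aromatic rings of carbon only, with no hydrogen-bond donors, no hydrogen-bond acceptors and no net charge. Nothing shown here bears on the cause of this large step.

On these data alone, the step changes the kind, number and placement of the halogens at once, so how much each of these contributes remains open. As far as these compounds go, how the number would respond to a methoxy group or a nitrile on this ring also remains open.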